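Cytotoxicity in a hydrazone urea series: from compound 3 to 4

This account rests on a few compounds, and the source may have more. Where it says the series, first, only, none or still open, it means among the compounds named here.

The compounds share one core and differ only in the aryl group on the carbon with a double bond to nitrogen. In an ADME assay on WI-38 cells (Homo sapiens) for cytotoxicity, read by MTT assay, with a stated time of 72 h (on this read-out higher numbers stand for weaker inhibition and lower numbers for stronger inhibition), compound 1 `CN(C)CCn1cnnc1-c1cc(Oc2ccc(NC(=O)N/N=C/c3ccc(O)c(Br)c3)cc2F)ccn1` gives 5560 nM and compound 2 `CN(C)CCn1cnnc1-c1cc(Oc2ccc(NC(=O)N/N=C/c3c(O)ccc4ccccc34)cc2F)ccn1` gives 3250 nM; the step of a 1.7-fold lower number from compound 1 to compound 2 (0.23 log units; within the scatter) shows that exchanging this aryl group left the read-out unchanged. In this assay compound 3 `CN(C)CCn1cnnc1-c1cc(Oc2ccc(NC(=O)N/N=C/c3cc(Br)c(O)c(Br)c3)cc2F)ccn1` gives "not determined" (no result reported), so no number exists for it. Compound 4 `CN(C)CCn1cnnc1-c1cc(Oc2ccc(NC(=O)N/N=C/c3ccc(F)cc3Cl)cc2F)ccn1` carries 2-chloro-4-fluorophenyl in place of 3,5-dibromo-4-hydroxyphenyl on a carbon with a double bond to nitrogen. Among the compounds with values here, the only measured step at this position, a 1.7-fold lower number from compound 1 to compound 2 (0.23 log units; within the scatter), stayed within the scatter, so for compound 4 no step beyond the scatter is expected in either direction. Compound 4 is therefore estimated at 4500 nM, with a range from 1500 nM to 15000 nM.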

Compound 4, half-maximal inhibitory concentration: 2090 nM
Estimate against measurement, compound 4: 2.2-fold (0.33 log units) above, and the stated range covers the measured number.
By their numbers in this assay, from the lowest: compounds 4, 2 and 1 (each within the scatter of the next, the first and the last beyond it).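

The change from compound 3 to compound 4 cannot be read, as compound 3 has no number. In this assay, this position now shows its first step beyond the scatter, though a modest one: a 2.7-fold lower number from compound 1 to compound 4 (0.42 log units; beyond the scatter), while a 1.6-fold lower number from compound 2 to compound 4 (0.19 log units; within the scatter) stays within it. Nothing measured here explains that difference. Still open, going by these compounds, is whether the chlorine and fluorine or the loss of the hydroxy group accounts for the step. An aryl group carrying an amine or a carboxylic acid on this carbon also remains untested in the compounds shown.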